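A few compounds are considered here, and "the series" means these few. Any claim that something is new, unique, unknown or untested is made for them only; others in the source may bear on it.

Compound 1 `COC(=O)/C=C/c1cccc(N(Cc2ccc(/C=C/c3c(Cl)cccc3Cl)cc2)C(=O)C2CCCCC2)c1` and compound 2 `COC(=O)/C=C/c1cccc(N(Cc2ccc(/C=C/c3cccc(F)c3)cc2)C(=O)NC(C)C)c1` share a core and were both tested in an assay on isolated protein with Bile acid receptor (Homo sapiens) as the target; a higher number here means that more compound is needed for the effect, a lower number that less compound is needed. Among the compounds with values here, compound 1 gives 151 nM, the lower of the two numbers, while compound 2 gives 468 nM, a higher number beyond the usual scatter; because the two differ in more than one place, no single step links them. Compound 3 `COC(=O)/C=C/c1cccc(N(Cc2ccc(/C=C/c3ccc(F)cc3)cc2)C(=O)C2CCCCC2)c1` differs from compound 1 in one place only: 4-fluorophenyl in place of 2,6-dichlorophenyl on a double-bonded chain carbon bound to a double-bonded chain carbon. Within the data shown here, no measured step of this kind exists here. A modest rise in the number for compound 3 is expected, a 2.6-fold higher number from compound 1 to compound 3 (0.42 log units; beyond the scatter). Compound 3 is thus estimated at 400 nM, with a likely range from 150 nM to 1200 nM.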

Compound 3, half-maximal effective concentration: 186 nM
Estimate against measurement, compound 3: 2.2-fold (0.33 log units) above, within the range that was stated.
By their numbers in this assay, from the lowest: compounds 1 and 3 (each within the scatter of the next); then compound 2.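

In this assay the swap of 2,6-dichlorophenyl for 4-fluorophenyl on a double-bonded chain carbon bound to a double-bonded chain carbon gives a 1.2-fold higher number from compound 1 to compound 3 (0.09 log units; within the scatter) and so leaves the number essentially unchanged. On this shared core, then, this position accepts either halogen-bearing phenyl group, despite the different halogen and the different pattern of substitution. No measurement shown gives a reason for this. On these data alone, whether a pyridine ring or a plain phenyl group would be accepted equally well remains open. So does whether a much larger group, such as naphthyl, would fit this pattern.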